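The source may report more compounds than this note shows. Statements on the series, on what has been measured and on what is new or still open speak of the compounds shown alone.

In an ADME assay on HEK-293T cells (Homo sapiens) for cytotoxicity, read by MTT assay, with a stated time of 48 h (a lower number here means that less compound is tolerated, a higher number that more compound is tolerated), compound 1 `CC1(C)[C@H]2CC[C@]1(C)[C@H](OC(=O)CCCCN1CCCCC1)C2` gives 101000 nM. Two other compounds built on the shared core give a first sense of the range. Compound 3 `CCOC(=O)N1CCN(CCC(=O)O[C@@H]2C[C@@H]3CC[C@@]2(C)C3(C)C)CC1` gives 110000 nM, which lies within the usual scatter of the value for compound 1. Compound 2 `CCOC(=O)N1CCN(CC(=O)O[C@@H]2C[C@@H]3CC[C@@]2(C)C3(C)C)CC1` gives 227000 nM, a gap from compound 1 that lies beyond the scatter, with more of compound 2 tolerated.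

Compound 4 `CC1(C)[C@H]2CC[C@]1(C)[C@H](OC(=O)CCCN1CCCCCC1)C2` has the same atoms as compound 1, joined differently: azepan-1-yl in place of (piperidin-1-yl)methyl on a saturated chain carbon, three bonds along the chain from a carbonyl carbon. Put simply, azepan-1-yl stands in place of (piperidin-1-yl)methyl on a saturated chain carbon, three bonds along the chain from a carbonyl carbon. Among the measured compounds shown here, no measured pair shows this kind of change directly, so any forecast is rough. The measured numbers run only from compound 1 at 101000 nM to compound 2 at 227000 nM, so no step beyond the scatter is expected in this assay. The expected step is a 1.1-fold lower number from compound 1 to compound 4 (0.05 log units; within the scatter). The estimate for compound 4 is 90000 nM, with an expected range from 45000 nM to 180000 nM.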

Compound 4, half-maximal cytotoxic concentration: 62200 nM
Compound 4: middle estimate off by 1.4-fold (0.16 log units), on the high side; low and high end bracket the measured number.
By their numbers in this assay, from the lowest: compounds 4, 1 and 3 (each within the scatter of the next); then compound 2.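

Exchanging (piperidin-1-yl)methyl for azepan-1-yl on a saturated chain carbon, three bonds along the chain from a carbonyl carbon, gives in this assay a step of a 1.6-fold lower number from compound 1 to compound 4 (0.21 log units; within the scatter). This is the first direct comparison among these compounds, and it shows that rearranging the same atoms, from a six-membered ring on a methyl link to a seven-membered ring bonded directly to the chain, leaves the two compounds indistinguishable in this test. No measurement available here explains this result.

A single pair cannot show how much this part of the molecule matters in general. Going by these compounds, whether a morpholine ring, a primary amine or a carboxylic acid at the chain end would move the number beyond the scatter remains open.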